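This account rests on a few compounds, and the source may have more. Where it says the series, first, only, none or still open, it means among the compounds named here.

Two compounds of the shared core have been run in a functional assay, with a stated time of 30 min; on this read-out lower numbers stand for stronger inhibition and higher numbers for weaker inhibition. Compound 1 `Cc1cccc(/C=N/c2ccc(OCc3ccccc3)cc2)c1O` returns only a limit of the assay, > 200000 nM. Compound 2 `COc1ccc(O)c(/C=N/c2ccc(OCc3ccccc3)cc2)c1` likewise returns only a limit, > 200000 nM. Compound 2 thus stands at the edge of what this assay can report, (the limit of > 200000 nM in this assay, at which 2 of the 2 values shown sit). Compound 3 `Oc1ccccc1/C=N/c1ccc(OCc2ccccc2)cc1` differs from compound 2 by hydrogen in place of methoxy on an aromatic carbon. Among the measured compounds shown here, no measured step exists to calibrate this change. The shift in this assay is expected to stay within the scatter, a number no higher from compound 2 to compound 3 (the limit leaves the size open). Compound 3 is expected to give 200000 nM, in the range 100000 nM to 400000 nM, most probably again as a limit only.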

Compound 3, half-maximal inhibitory concentration: > 200000 nM
Compound 3 gave a limit, no number; the forecaster's own chance of this, stated with the estimate: 85%; the middle value lies on the limit itself.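

Among the compounds shown here, compound 1, compound 2 and compound 3 each give only a limit in this assay, so no step among them can be read: the limit of > 200000 nM in this assay, at which 3 of the 3 values shown sit. The compounds shown leave open whether any change on the shared core gives a readable number in this assay.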